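Sulfonyl aryl swap from compound 2 to compound 4

The compounds below may be only part of what the source reports. "The series", "measured", "known", "first", "only" and "open" are said of these compounds alone.

Three compounds carry measurements in an assay on cells for inhibition of HSP60/HSP10 (Homo sapiens), with a stated time of 60 min; on this read-out higher numbers stand for weaker inhibition and lower numbers for stronger inhibition. Compound 1 `N#Cc1ccc(S(=O)(=O)Nc2ccc(-c3nc4cc(NS(=O)(=O)c5ccc(C#N)cc5)ccc4o3)cc2)cc1` gives 49000 nM. Compound 2 `Cc1ccccc1S(=O)(=O)Nc1ccc2oc(-c3ccccc3)nc2c1` returns only the limit > 100000 nM, not a number. Compound 3 `O=S(=O)(Nc1ccc(-c2nc3ccccc3o2)cc1)c1ccccc1O` likewise sits at the limit > 100000 nM. Compound 2 thus stands at the limit of > 100000 nM in this assay, at which 2 of the 3 values shown sit, and no ordering among these values can be drawn beyond that.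

Compound 4 `O=S(=O)(Nc1ccc2oc(-c3ccccc3)nc2c1)c1cccc(Cl)c1` is not yet measured. It differs from compound 2 in one place: 3-chlorophenyl in place of 2-methylphenyl on a sulfonyl sulfur. Among the compounds with values here, no step between measured compounds is recorded, and no measured pair involves a change on the sulfonyl-bound aryl group, so the size of the step cannot be read from the data. The expectation is for no step beyond the scatter, with compound 4 remaining at or near the limit. The expected step is a number no higher from compound 2 to compound 4 (the limit leaves the size open). Compound 4 is estimated at 100000 nM, with a range from 40000 nM to 250000 nM, and is most likely to be reported as a limit again.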

Compound 4, half-maximal inhibitory concentration: > 100000 nM
Compound 4: only a limit was reported (the forecaster's own chance of this, stated with the estimate: 65%); the middle value lies on the limit itself.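

Compound 2 and compound 4 both sit at a limit in this assay, so no step can be read for the swap from 2-methylphenyl to 3-chlorophenyl. The compounds shown leave open how large any difference between these two sulfonyl-bound groups is, and in which direction it runs.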